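This account rests on a few compounds, and the source may have more. Where it says the series, first, only, none or still open, it means among the compounds named here.

In a functional assay with Homo sapiens as the target (on this read-out lower numbers stand for stronger inhibition and higher numbers for weaker inhibition), compound 1 `CC(C)[C@H](NC(=O)COc1cccc2ccccc12)C(=O)N[C@@H](CC(=O)O)C(=O)COc1cccc2ccccc12` gives 19000 nM while compound 2 `CC(C)[C@H](NC(=O)COc1cccc2ccccc12)C(=O)N[C@@H](CC(=O)O)C(=O)COc1ccc2ccccc2c1` gives 15900 nM and compound 3 `CC(C)[C@H](NC(=O)COc1cccc2ccccc12)C(=O)N[C@@H](CC(=O)O)C(=O)COc1ccc(C(F)(F)F)cc1` gives 12300 nM on the same read-out. Compound 3 stands level with both others on these numbers, and a 1.2-fold lower number from compound 1 to compound 2 (0.08 log units; within the scatter) also stays within the scatter. The change to compound 4 `CC(C)[C@H](NC(=O)COc1cccc2ccccc12)C(=O)N[C@@H](CC(=O)O)C(=O)COc1ccc(C#N)cc1` is cyano in place of trifluoromethyl on an aromatic carbon and amounts to cyano in place of trifluoromethyl on an aromatic carbon, para to a large group. Among the compounds with values here, no measured step makes this exchange alone. Only the replacements of the whole group on the oxygen bear on it, and a 1.5-fold lower number from compound 1 to compound 3 (0.19 log units; within the scatter) and a 1.3-fold lower number from compound 2 to compound 3 (0.11 log units; within the scatter) stay within the scatter. In this assay the expected step is a 1.1-fold higher number from compound 3 to compound 4 (0.06 log units; within the scatter) and so none beyond the scatter. Compound 4 is estimated at 14000 nM with a range from 7000 nM to 26000 nM.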

Compound 4, half-maximal inhibitory concentration: 26700 nM
Compound 4: middle estimate off by 1.9-fold (0.28 log units), on the low side, and the stated range ends below it.
By their numbers in this assay, from the lowest: compounds 3, 2, 1 and 4 (each within the scatter of the next, the first and the last beyond it).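

Cyano in place of trifluoromethyl on this aromatic carbon gives the only step beyond the scatter among these compounds in this assay (a 2.2-fold higher number from compound 3 to compound 4 (0.34 log units; beyond the scatter)), so a change confined to this substituent registers where replacing the whole group on the oxygen did not. Compound 4 still stays level with the two naphthalene compounds (a 1.7-fold higher number from compound 2 to compound 4 (0.23 log units; within the scatter); a 1.4-fold higher number from compound 1 to compound 4 (0.15 log units; within the scatter)), so it stands apart from compound 3 alone. Nothing available explains this step. Going by these compounds, whether an amine, a methoxy group or a carboxylic acid on this carbon would sit nearer compound 3 or compound 4 stays open. So does whether the step holds on a changed core.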